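The compounds below may be only part of what the source reports. "The series", "measured", "known", "first", "only" and "open" are said of these compounds alone.

Compound 1 `CNc1nc(NCc2ccc(NC(=O)c3ccncc3)cc2)c2ccccc2n1` was tested in a functional assay on SW480 cells (Homo sapiens) for inhibition, read by luminescence and resazurin assay, with a stated time of 3 days; a lower number here means a stronger inhibitor, a higher number a weaker inhibitor. In this assay compound 1 gives only a limit, > 20000 nM. Its near relative compound 2 `CN(C)c1nc(NCc2ccc(NC(=O)c3ccncc3)cc2)c2ccccc2n1`, carrying methyl in place of hydrogen on a nitrogen on an aromatic ring, gives 11000 nM in this assay; the step of an at least 1.8-fold lower number from compound 1 to compound 2 (0.25 log units; that floor lies within the scatter) is the only measured one, and it rests on the limit of > 20000 nM in this assay, at which 1 of the 2 values shown sits, for compound 1. Compound 3 `CNc1nc(NCc2ccc(NC(=O)c3ccc(F)cc3)cc2)c2ccccc2n1` has not been measured; it differs from compound 1 by 4-fluorophenyl in place of pyridin-4-yl on a carbonyl carbon. Within the data shown here, no measured step touches the group on the carbonyl carbon, so nothing among the measured compounds points to a direction for this change, and compound 1 itself stands only at a limit. The expected step that the limit leaves unreadable from compound 1 to compound 3 is therefore taken as none beyond the scatter. Compound 3 is thus expected near 25000 nM, within 8000 nM to 80000 nM, with a fair chance that this assay again reports only a limit.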

Compound 3, half-maximal inhibitory concentration: 2000 nM
The estimate for compound 3 lay 13-fold (1.10 log units) above the measured number; measured number below the stated range.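

In this assay, the group on the carbonyl carbon proves to be a position where a single change has a clear effect: 4-fluorophenyl in place of pyridin-4-yl gives an at least 10-fold lower number from compound 1 to compound 3 (1.00 log units; beyond the scatter). Among these compounds, the earlier step, on the nitrogen, had a floor within the scatter, whereas this floor lies beyond it, so the first change to this group shows more than the nitrogen step could. The size remains only a floor, and the full step cannot be read, as compound 1 stands at a limit: the limit of > 20000 nM in this assay, at which 1 of the 3 values shown sits.

The compounds shown leave open whether the fluorine or the carbon-only ring accounts for the step, a question that plain phenyl or 4-chlorophenyl on the carbonyl carbon would address. Also open, from the compounds shown here alone, is whether the added methyl of compound 2 would lower the number further alongside 4-fluorophenyl.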